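Carbamate side-chain branching in the shared series

The source may report more compounds than this note shows. Statements on the series, on what has been measured and on what is new or still open speak of the compounds shown alone.

Compound 1 `COc1cc(C(=O)N2CCN(C(=O)c3cc(OC)c(OC)c(OC)c3)C(COC(=O)C(C)(C)C)C2)cc(OC)c1OC` gives 300 nM; 300 nM; 420 nM (3 entries) in an assay (Oryctolagus cuniculus) for binding affinity to platelet-activating factor receptor (Cavia porcellus) (a higher number here means that more compound is needed for the effect, a lower number that less compound is needed), and compound 2 `CCC(CC)C(=O)OCC1CN(C(=O)c2cc(OC)c(OC)c(OC)c2)CCN1C(=O)c1cc(OC)c(OC)c(OC)c1` gives 250 nM; 90 nM; 220 nM (3 entries); both carry ester side chains, one of them branched. For the measured compounds named here, compound 3 `CCCCNC(=O)OCC1CN(C(=O)c2cc(OC)c(OC)c(OC)c2)CCN1C(=O)c1cc(OC)c(OC)c(OC)c1` carries a butyl carbamate instead and gives 700 nM, the only number for it in this assay, with two further entries that returned no number. Compound 4 `COc1cc(C(=O)N2CCN(C(=O)c3cc(OC)c(OC)c(OC)c3)C(COC(=O)NC(C)C(C)C)C2)cc(OC)c1OC` is not yet measured and differs from compound 3 by 1,2-dimethylpropyl in place of butyl on an amide-type nitrogen. Going by the values given here, no step between measured compounds is available to read the effect of branching directly, and the entries of compound 2 (the several entries of compound 2 in this assay, 250 nM; 90 nM; 220 nM (3 entries)) and of compound 1 (the several entries of compound 1 in this assay, 300 nM; 300 nM; 420 nM (3 entries)) each spread on their own. A step of a 1.4-fold lower number from compound 3 to compound 4 (0.15 log units; within the scatter) is expected in this assay, not beyond the scatter. Compound 4 is estimated at 500 nM, in the range 200 nM to 1500 nM.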

Compound 4, half-maximal effective concentration: 70 nM
For compound 4 the middle estimate is 7.1-fold (0.85 log units) above the measured one, and the stated range ends above it.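

In this assay, for the compounds shown here, 1,2-dimethylpropyl in place of butyl on the amide-type nitrogen gives a 10-fold lower number from compound 3 to compound 4 (1.00 log units; beyond the scatter), the first reading of a change at this position, which the ester side chains of compound 1 and compound 2 could not supply. The step is wider than the spread among repeated entries of a single compound: the several entries of compound 2 in this assay, 250 nM; 90 nM; 220 nM (3 entries)

Each end of the step rests on a single number, and 1,2-dimethylpropyl differs from butyl in both branching and carbon count, so the two remain unseparated. A straight pentyl chain on the same nitrogen would separate them.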